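The compounds below may be only part of what the source reports. "The series", "measured", "known", "first", "only" and "open" are said of these compounds alone.

Measured compounds in an assay on a protein complex for inhibition of integrin alpha-5/beta-1 (Homo sapiens), read by ELISA; a lower number here means a stronger inhibitor, a higher number a weaker inhibitor:
compound 1 `COc1ccnc(NC[C@@H]2C[C@@H](OCC(=O)NC[C@H](NC(=O)C3(C)CCCCC3)C(=O)O)CN2C(=O)OCc2ccccc2)c1` gives 0.8 nM
compound 2 `Cc1cc(C)c(C(=O)N[C@@H](CNC(=O)CO[C@@H]2C[C@@H](CNc3ccccn3)N(C(=O)OCc3ccccc3)C2)C(=O)O)c(C)c1` gives 3.5 nM
compound 3 `COc1ccnc(NC[C@@H]2C[C@@H](OCC(=O)NC[C@H](NS(=O)(=O)c3c(C)cc(C)cc3C)C(=O)O)CN2C(=O)OCc2ccccc2)c1` gives 1.1 nM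

Compound 3 stands second highest of the three numbers in this assay. Its nearest neighbour is compound 1, a step that is within the scatter: a 1.4-fold higher number from compound 1 to compound 3 (0.14 log units; within the scatter). The furthest is compound 2, whose number lies beyond the scatter from that of compound 3.

Compound 4 `COc1ccnc(NC[C@@H]2C[C@@H](OCC(=O)NC[C@H](NC(=O)c3c(C)cc(C)cc3C)C(=O)O)CN2C(=O)OCc2ccccc2)c1` is the next member. It differs from compound 3 in one place: (2,4,6-trimethylphenyl)carbonyl in place of (2,4,6-trimethylphenyl)sulfonyl on an amine nitrogen. For the measured compounds named here, only one measured step touches the same amine nitrogen, and that is the exchange from compound 1 to compound 3, which changed the number by no more than the scatter. Compound 2 carries the same (2,4,6-trimethylphenyl)carbonyl group as compound 4 but on a different core, so its value can only be noted, not turned into a step. On this basis a small step is expected in this assay, with no direction that can be read from the measured steps; the estimate places the change at a 1.4-fold higher number from compound 3 to compound 4 (0.13 log units; within the scatter). For compound 4 the number is estimated at 1.5 nM, with a range from 0.6 nM to 4 nM.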

Compound 4, half-maximal inhibitory concentration: 0.54 nM
The estimate for compound 4 lay 2.8-fold (0.44 log units) above the measured number; measured number below the stated range.
By their numbers in this assay, from the lowest: compounds 4, 1 and 3 (each within the scatter of the next, the first and the last beyond it); then compound 2.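

In this assay the amine nitrogen now separates two groups: (2,4,6-trimethylphenyl)carbonyl in place of (2,4,6-trimethylphenyl)sulfonyl gives a 2.0-fold lower number from compound 3 to compound 4 (0.31 log units; beyond the scatter), a modest step, whereas the exchange read earlier at this nitrogen gave only a 1.4-fold higher number from compound 1 to compound 3 (0.14 log units; within the scatter) and stayed within the scatter. On the carbonyl carbon, 2,4,6-trimethylphenyl in place of 1-methylcyclohexyl gives a 1.5-fold lower number from compound 1 to compound 4 (0.17 log units; within the scatter), so these two groups cannot be told apart in this assay. For the compounds shown here, compound 4 also supplies the first direct reading of the methoxy on the aromatic carbon, since methoxy in place of hydrogen with the same (2,4,6-trimethylphenyl)carbonyl group gives a 6.5-fold lower number from compound 2 to compound 4 (0.81 log units; beyond the scatter), the larger of the two steps beyond the scatter among the new ones.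

Nothing available here explains any of these steps. From the compounds shown here alone, it remains open whether the carbonyl-over-sulfonyl step holds for groups other than 2,4,6-trimethylphenyl, such as a methanesulfonyl or a 1-methylcyclohexylsulfonyl group on the same nitrogen, and whether an ethoxy or a dimethylamino group on the same aromatic carbon would match the methoxy.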